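The source may report more compounds than this note shows. Statements on the series, on what has been measured and on what is new or still open speak of the compounds shown alone.

Compound 1 `N#CCCCn1c(Cn2c(=O)n(-c3ncccn3)c3ccncc32)cc2cc(Cl)ccc21`: in an ADME assay on HeLa cells (Homo sapiens) for cytotoxicity, read by ATP content, with a stated time of 3 days (a higher number here means that more compound is tolerated, a lower number that less compound is tolerated), compound 1 gives > 50000 nM, which is a limit of the assay.
Compound 2 `COc1ccc(-n2c(=O)n(Cc3cc4cc(Cl)ccc4n3CCCC#N)c3cnccc32)c(C)c1`: in this assay compound 2 gives > 50000 nM, again a limit of the assay.

Compound 2 therefore stands at the limit where both measured values sit (the limit of > 50000 nM in this assay, at which 2 of the 2 values shown sit). The step that the two limits leave unreadable from compound 1 to compound 2 stays unreadable between two limits. Compound 3 `Cc1ccc(-n2c(=O)n(Cc3cc4cc(Cl)ccc4n3CCCC#N)c3cnccc32)cc1` differs from compound 2 by 4-methylphenyl in place of 4-methoxy-2-methylphenyl on an aromatic nitrogen. Among the measured compounds shown here, no measured step bears on this change, so no size of step in this assay can be drawn from the data. Compound 3 is expected to remain at the limit, with a step of a number no higher from compound 2 to compound 3 (the limit leaves the size open) not beyond the scatter. Compound 3 is estimated at 50000 nM, between 25000 nM and 100000 nM.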

Compound 3, half-maximal cytotoxic concentration: > 50000 nM
Compound 3: a limit, no number; the forecaster's own chance of this, stated with the estimate: 85%; the middle value sits exactly at the limit.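

No new step can be read between compound 1, compound 2 and compound 3, because each value is only a limit of the assay: the limit of > 50000 nM in this assay, at which 3 of the 3 values shown sit.

The compounds shown leave open whether the groups on the aromatic nitrogen differ at all in this assay.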